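Nitro for Ethyl on a Biaryl Amide Scaffold

The source may hold more compounds than are shown below. What is called first, only, known or untested is meant among the compounds shown, and "the series" means these compounds.

Compound 2 `CCc1cc(C(=O)N[C@H](C)CCCc2cccnc2)ccc1-c1ccc(OC)c(OC)c1` gives 4 nM in an assay (Canis lupus familiaris) for binding affinity to platelet-activating factor receptor (Homo sapiens), read by radioligand binding (a higher number here means a weaker inhibitor, a lower number a stronger inhibitor), the lowest of the two numbers at hand. Its nearest neighbour, compound 1 `COc1cccc(-c2ccc(C(=O)N[C@H](C)CCCc3cccnc3)cc2)c1`, gives 20 nM in this assay, a gap that lies beyond the usual scatter; the two differ in more than one place, so the comparison shows only what the values themselves say. Compound 3 `COc1ccc(-c2ccc(C(=O)N[C@H](C)CCCc3cccnc3)cc2[N+](=O)[O-])cc1OC` has not yet been measured. Relative to compound 2 it carries nitro in place of ethyl on an aromatic carbon, that is, nitro in place of ethyl on an aromatic carbon, ortho to a 3,4-dimethoxyphenyl group and meta to a large group. For the measured compounds named here, no measured pair shows this change, so the size of the step is open. Compound 3 is expected to come in at 8 nM, with a plausible range from 2 nM to 30 nM. The step from compound 2 to compound 3 is thus estimated as a 2.0-fold higher number from compound 2 to compound 3 (0.30 log units; within the scatter), a modest weakening that may not exceed the scatter.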

Compound 3, half-maximal inhibitory concentration: 200 nM
Estimate against measurement, compound 3: 25-fold (1.40 log units) below; the measured number lies above the stated range.
By their numbers in this assay, from the lowest: compound 2; then compound 1; then compound 3.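

In this assay nitro in place of ethyl on an aromatic carbon, ortho to a 3,4-dimethoxyphenyl group and meta to a large group, gives a 50-fold higher number from compound 2 to compound 3 (1.70 log units; beyond the scatter) and so provides the first reading of a change in one place among these compounds. It shows that this position is not indifferent to the group it carries, since exchanging ethyl for nitro there moves the number well beyond the scatter. Nothing at hand speaks to what lies behind this large step.

As far as these compounds go, with a single pair bearing on this position, how a hydrogen, a chlorine atom, an amine or a propyl chain would stand there remains open. Also open, from the compounds shown here alone, is whether nitro for ethyl would give a step of similar size with a different aryl group on the shared core.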